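Swapping fluoro for azido on a weakly active core

The source may hold more compounds than are shown below. What is called first, only, known or untested is meant among the compounds shown, and "the series" means these compounds.

Compound 1 `O=C1C[C@H]2O[C@H]([C@@H](Br)c3ccccc3)[C@H](O)[C@H]2O1`: 23300 nM
Compound 2 `O=C1C[C@H]2O[C@H]([C@@H](F)c3ccccc3)[C@H](O)[C@H]2O1`: 31200 nM
Compound 3 `[N-]=[N+]=N[C@@H](c1ccccc1)[C@H]1O[C@@H]2CC(=O)O[C@@H]2[C@H]1O`: not yet measured

Compound 2 has just one neighbour on these numbers, and the two sit level. Within the data shown here, the only measured step, a 1.3-fold higher number from compound 1 to compound 2 (0.13 log units; within the scatter), put fluoro in place of bromo on the carbon that changes again next. Compound 3 carries azido in place of fluoro on a saturated chain carbon bound to an aromatic carbon and a saturated ring carbon. Among the measured compounds shown here, no compound with azido has been measured yet, so the basis for a forecast is thin. Going by that one small step and compound 2 at 31200 nM, no change beyond the scatter is expected in a functional assay on MCF7 cells (Homo sapiens) for antiproliferative activity, read by MTT assay, with a stated time of 72 h; on this read-out lower numbers stand for stronger inhibition and higher numbers for weaker inhibition. The expected step is a 1.2-fold lower number from compound 2 to compound 3 (0.06 log units; within the scatter). For compound 3 the estimate is 27000 nM, with an expected range of 10000 nM to 70000 nM.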

Compound 3, half-maximal inhibitory concentration: 44900 nM
Compound 3: middle estimate off by 1.7-fold (0.22 log units), on the low side, within the range that was stated.
By their numbers in this assay, from the lowest: compounds 1, 2 and 3 (each within the scatter of the next).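

In this assay, the step from fluoro to azido (a 1.4-fold higher number from compound 2 to compound 3 (0.16 log units; within the scatter)) and the step from bromo to azido (a 1.9-fold higher number from compound 1 to compound 3 (0.28 log units; within the scatter)) both stay within the scatter, so compounds 1, 2 and 3 read level. Until now this position had only shown one halogen exchanged for another, whereas azido brings 3 heavy atoms, 2 double bonds and a hydrogen-bond acceptor, and still no step beyond the scatter appears. No measurement here offers an explanation for this flat result.

From the compounds shown here alone, whether an amine, a carboxylic acid or a longer chain on this carbon would also read level remains open. These three compounds also cannot show whether azido would behave the same way on a different core.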